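Replacing the amide linker with a pyrimidinyl amine

This account rests on a few compounds, and the source may have more. Where it says the series, first, only, none or still open, it means among the compounds named here.

Measured compounds:
compound 1 `CC(O)c1cccc(C(=O)N[C@@H](C)Cn2ccc(-c3ccc(C#N)c(Cl)c3)n2)c1` gives 2280 nM in a functional assay on LNCaP cells (Homo sapiens) for antiproliferative activity, read by CCK-8 assay, with a stated time of 6 days; on this read-out lower numbers stand for stronger inhibition and higher numbers for weaker inhibition
compound 2 `CC(O)c1ccc(C(=O)N[C@@H](C)Cn2ccc(-c3ccc(C#N)c(Cl)c3)n2)cc1` gives 3690 nM in this assay
compound 3 `COC(=O)/C=C/C(=O)N[C@@H](C)Cn1ccc(-c2ccc(C#N)c(Cl)c2)n1` gives 2460 nM in this assay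

Compound 3 stands second highest of the three numbers, with compound 1 nearest and compound 2 furthest; all three lie within the scatter of one another. The measured steps are a 1.1-fold higher number from compound 1 to compound 3 (0.03 log units; within the scatter), a 1.5-fold lower number from compound 2 to compound 3 (0.18 log units; within the scatter) and a 1.6-fold higher number from compound 1 to compound 2 (0.21 log units; within the scatter), none beyond the scatter, and each swaps only the group on the carbonyl carbon.

Compound 4 `C[C@@H](Cn1ccc(-c2ccc(C#N)c(Cl)c2)n1)Nc1cncnc1` is different: pyrimidin-5-yl in place of (2-(methoxycarbonyl)ethenyl)carbonyl on an amine nitrogen. Here the carbonyl itself leaves, so no measured step covers this kind of change. The three measured steps show that the acyl part of compound 3 tolerates exchange without a step beyond the scatter, but they say nothing about losing the carbonyl. He therefore expects for compound 4 a step of a 1.0-fold higher number from compound 3 to compound 4 (0.01 log units; within the scatter) that stays within the scatter, with wide uncertainty. His estimate for compound 4 is 2500 nM, expected to fall between 700 nM and 9000 nM.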

Compound 4, half-maximal inhibitory concentration: 2070 nM
Compound 4: middle estimate off by 1.2-fold (0.08 log units), on the high side; the measured number falls inside the stated range.
By their numbers in this assay, from the lowest: compounds 4, 1, 3 and 2 (each within the scatter of the next).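

In this assay, putting pyrimidin-5-yl in place of (2-(methoxycarbonyl)ethenyl)carbonyl on the amine nitrogen gives a 1.2-fold lower number from compound 3 to compound 4 (0.07 log units; within the scatter). The earlier steps shown here only exchanged the group on the carbonyl carbon, whereas this one removes the carbonyl itself, and the number still stays within the scatter, so in this pair the amide carbonyl is not required for a value of this size. Nothing measured here accounts for this result.

From the compounds shown here alone, whether a pyridin-3-yl or pyrimidin-2-yl group, or a plain methyl, on that amine nitrogen would also stay within the scatter of compound 4 remains open. Since every step shown lies within the scatter, the compounds shown also leave open what change on this nitrogen would move the number at all.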